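The source may hold more compounds than are shown below. What is called first, only, known or untested is meant among the compounds shown, and "the series" means these compounds.

Measured so far in a functional assay on DU-145 cells (Homo sapiens) for antiproliferative activity, read by MTT assay, with a stated time of 72 h; on this read-out higher numbers stand for weaker inhibition and lower numbers for stronger inhibition:
compound 1 `O=C1OCC[C@@H]1NC(=S)SCCOc1ccc([N+](=O)[O-])cc1` gives 31000 nM
compound 2 `O=C1OCC[C@@H]1NC(=S)SCCOc1ccccc1` gives 63800 nM
compound 3 `CCOc1ccccc1OCCSC(=S)N[C@H]1CCOC1=O` gives 28300 nM

Compound 2 has the highest number of the three, so it is the weakest inhibitor among them in this assay. Compound 4 `CC(=O)c1ccc(OCCSC(=S)N[C@H]2CCOC2=O)cc1` differs from compound 2 by acetyl in place of hydrogen on an aromatic carbon of a six-membered aromatic ring of carbon only, para to a large group. Two measured steps change a group on an aromatic carbon of this ring: a 2.1-fold higher number from compound 1 to compound 2 (0.31 log units; beyond the scatter), and a 2.3-fold lower number from compound 2 to compound 3 (0.35 log units; beyond the scatter). Both point the same way: the bare ring carbon goes with the higher number, a substituted one with a lower number, though only these two pairs support this. A modest lowering is therefore expected for compound 4, a 2.1-fold lower number from compound 2 to compound 4 (0.33 log units; beyond the scatter). Compound 4 is thus estimated at 30000 nM in this assay, between 12000 nM and 80000 nM.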

Compound 4, half-maximal inhibitory concentration: 32600 nM
For compound 4 the middle estimate is 1.1-fold (0.04 log units) below the measured one; the range from low to high includes it.
By their numbers in this assay, from the lowest: compounds 3, 1, 4 and 2 (each within the scatter of the next, the first and the last beyond it).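

Putting acetyl in place of hydrogen on this ring carbon, para to a large group, gives a 2.0-fold lower number from compound 2 to compound 4 (0.29 log units; within the scatter), so compound 4 cannot be told apart from the unsubstituted compound 2. Acetyl in place of nitro gives a 1.1-fold higher number from compound 1 to compound 4 (0.02 log units; within the scatter), so these two groups cannot be told apart here either, and the link between a substituted ring carbon and a lower number rests on small gaps. No available evidence bears on these steps. Going by these compounds, whether an amine or a carboxylic acid at this place would give a step clearly beyond the scatter remains open.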